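The source may report more compounds than this note shows. Statements on the series, on what has been measured and on what is new or still open speak of the compounds shown alone.

Within the data shown here, compound 1 `Cc1nc(N)nc(N[C@@H](C)c2cc3ccc(F)cn3c(=O)c2-c2ccccc2)c1C#N` is the only member of this set with a result: in an ADME assay on microsomes from liver (Mus musculus), read by LC-MS, using NADPH, with a stated time of 30 min, tested at 1 uM (a higher number here means that more of the compound is left, a lower number that less of the compound is left), compound 1 gives 8%. Compound 2 `Cc1c([C@H](C)Nc2ncnc(N)c2C#N)c(-c2ccc(F)cc2)c2ccc(F)cn2c1=O` shares the aminopyrimidine nitrile and the fused core motif but carries a 4-fluorophenyl group, and in this assay compound 2 has "not determined" (no result reported), so there is no number on which compound 2 stands. Compound 3 `C[C@H](Nc1ncnc(N)c1C#N)c1c(C2CC2)c(=O)n2cc(F)ccc2c1-c1ccc(F)cc1` differs from compound 2 in one place: cyclopropyl in place of methyl on an aromatic carbon. No measured step between any two of these compounds exists, so the size and direction of the change from compound 2 to compound 3 in this assay cannot be read from a comparable pair; the only anchor is the low value of compound 1. On that basis compound 3 is expected to leave little of the compound, with an estimate of 12% and a range from 2% to 40%.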

Compound 3, percent of the compound remaining: 52%
Beside the measured number, compound 3's estimate is 40 percentage points below it; the measured number lies above the stated range.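

In this assay, among these compounds, compound 3 gives 52% and compound 2 has no number, and no step from compound 2 to compound 3 can be read. From the compounds shown here alone, what cyclopropyl in place of methyl does to this read-out stays open. Nothing shown bears on the result.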